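A Phenyl for a Benzyl on Compound 3

The source may hold more compounds than are shown below. What is called first, only, known or untested is meant among the compounds shown, and "the series" means these compounds.

Of the compounds shown here, three sharing one core have been tested in a functional assay on Jurkat cells (Homo sapiens) for inhibition, read by CCK-8 assay, with a stated time of 48 h; on this read-out higher numbers stand for weaker inhibition of growth and lower numbers for stronger inhibition of growth. Compound 1 `Cc1ccccc1Nc1nc(NC2CC2)ncc1Cl` gives > 100000 nM, which is a limit of the assay and not a number.

The other two give true numbers. Compound 2 `Cc1ccccc1Nc1nc(Nc2ccc(N3CCN(C)CC3)cn2)ncc1Cl` gives 8080 nM, and compound 3 `COc1ccc(CNc2nc(Nc3ccc(N4CCN(C)CC4)cn3)ncc2Cl)cc1` gives 12900 nM. Within the data shown here, compound 3 therefore stands within the scatter of compound 2, the only other true number available, and the comparison between them reads a 1.6-fold higher number from compound 2 to compound 3 (0.20 log units; within the scatter).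

Compound 4 `CCc1ccc(Nc2nc(Nc3ccc(N4CCN(C)CC4)cn3)ncc2Cl)cc1` has not yet been measured. It has 4-ethylphenyl in place of 4-methoxybenzyl on a nitrogen on an aromatic ring, and the count of what changes is 4-ethylphenyl in place of 4-methoxybenzyl on a nitrogen on an aromatic ring.

Among the measured compounds shown here, only one measured step bears on this change, since it swaps groups at the same place: a 1.6-fold higher number from compound 2 to compound 3 (0.20 log units; within the scatter). That is a single comparison, so it offers limited guidance, but it gives no reason to expect a step beyond the scatter in this assay. The expected change is small, with no firm direction, and is estimated as a 1.3-fold lower number from compound 3 to compound 4 (0.11 log units; within the scatter). For compound 4 the estimate is 10000 nM, with an expected range from 3500 nM to 30000 nM.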

Compound 4, concentration for 50% growth inhibition: 11100 nM
Compound 4: middle estimate off by 1.1-fold (0.05 log units), on the low side; measured number inside the range.
By their numbers in this assay, from the lowest: compounds 2, 4 and 3 (each within the scatter of the next). At a limit, above all of these: compound 1.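

Until now this position had offered a single comparison, between 2-methylphenyl and 4-methoxybenzyl. In this assay, the new compound gives two more, a 1.2-fold lower number from compound 3 to compound 4 (0.07 log units; within the scatter) and a 1.4-fold higher number from compound 2 to compound 4 (0.14 log units; within the scatter), so all three groups on this nitrogen now stand within the scatter of one another. The change from 4-methoxybenzyl to 4-ethylphenyl removes the oxygen and its hydrogen-bond acceptor and places the ring on the nitrogen without the benzyl carbon, yet this gives no step beyond the scatter, and nothing shown here offers a reason for that.

Going by these compounds, all three groups are hydrocarbon-based aromatic rings with small substituents, so it remains open whether a ring carrying an amine or a carboxylic acid, or a plain alkyl chain with no ring at all, would stay within the scatter at this position. On these data alone, it is also open whether a change at this nitrogen would matter more on a compound with a lower number, since these three compounds share the same group at the other substituted nitrogen and none reaches a much lower number.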